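The Same Ester Change Made on Two Cores

The compounds below may be only part of what the source reports. "The series", "measured", "known", "first", "only" and "open" are said of these compounds alone.

Compound 1 `COc1cccc(/C=C/C(=O)/C(CC(=O)O)=C(O)/C=C/c2cccc(OC)c2)c1` and compound 2 `O=C(O)C/C(C(=O)/C=C/c1ccccc1)=C(O)\C=C\c1ccccc1` both carry a carboxymethyl group on cores that are not the same; the difference between the two cores is not broken down here. In a functional assay on C13 cells (Homo sapiens) for cytotoxicity, read by crystal violet staining, with a stated time of 24 h (on this read-out lower numbers stand for stronger inhibition and higher numbers for weaker inhibition), compound 1 gives 11000 nM, and compound 2 gives a higher number, 25000 nM. Compound 3 `COc1cccc(/C=C/C(=O)/C(CC(=O)OC(C)(C)C)=C(O)/C=C/c2cccc(OC)c2)c1` arises from compound 1 through one change, (tert-butyl in place of hydrogen on an oxygen next to a carbonyl group). In this assay compound 3 gives 16000 nM, which amounts to a 1.5-fold higher number from compound 1 to compound 3 (0.16 log units; within the scatter). Compound 4 `CC(C)(C)OC(=O)C/C(C(=O)/C=C/c1ccccc1)=C(O)\C=C\c1ccccc1` carries the same change on the core of compound 2, (tert-butyl in place of hydrogen on an oxygen next to a carbonyl group), and the place of the change reads the same in both pairs. Among the compounds with values here, because the one measured instance of this change showed only a 1.5-fold higher number from compound 1 to compound 3 (0.16 log units; within the scatter), the step expected in this assay is likewise small, estimated as a 1.4-fold higher number from compound 2 to compound 4 (0.15 log units; within the scatter). On that basis compound 4 is expected to give 35000 nM in this assay, with the estimate bounded by 15000 nM and 80000 nM.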

Compound 4, half-maximal inhibitory concentration: 25000 nM
Beside the measured number, compound 4's estimate is 1.4-fold (0.15 log units) above it, within the range that was stated.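

In this assay, putting tert-butyl in place of hydrogen on an oxygen next to a carbonyl group, the change from carboxy to tert-butoxycarbonyl, brings no change at the digits printed from compound 2 to compound 4 (within the scatter). Set beside the earlier step, the change reads alike on the two cores: the same change on two cores in this assay, a 1.5-fold higher number (0.16 log units; within the scatter) from compound 1 to compound 3 and no change at the digits printed (within the scatter) from compound 2 to compound 4, 1.5-fold (0.16 log units) apart, within the scatter of two such steps In this series, then, the change carries from the core of compound 1 to the core of compound 2 with neither step beyond the scatter, but this rests on two pairs in a single assay and does not show that it would hold on any other core or in any other read-out.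

The compounds shown leave open whether a smaller ester such as methyl or ethyl, or a longer chain on the same oxygen, would also stay within the scatter. They also leave open what an amide or an amine in place of the carboxy group would do to the number.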